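This account rests on a few compounds, and the source may have more. Where it says the series, first, only, none or still open, it means among the compounds named here.

In a functional assay on CFPAC-1 cells (Homo sapiens) for antiproliferative activity, read by MTT assay, with a stated time of 72 h (on this read-out lower numbers stand for stronger inhibition and higher numbers for weaker inhibition), compound 3 `CCCCCc1ccc(C#Cc2c(-c3ccc(CCCCC)cc3)oc3nc(=O)n(Cc4cn(-c5ccccc5F)nn4)cc23)cc1` gives only a limit, > 100000 nM. Its closest measured relative, compound 2 `CCCCCc1ccc(C#Cc2c(-c3ccc(CCCCC)cc3)oc3nc(=O)n(Cc4cn(Cc5ccccc5)nn4)cc23)cc1`, likewise returns only a limit in this assay, > 100000 nM. The step that the two limits leave unreadable from compound 2 to compound 3 therefore cannot be sized because both ends sit at the limit of > 100000 nM in this assay, at which 2 of the 3 values shown sit. For the measured compounds named here, the one compound with an actual number, compound 1 `O=c1nc2oc(CCCCl)c(C#CCCCCCl)c2cn1Cc1cn(-c2ccc(F)cc2)nn1`, gives 95800 nM in this assay, a weak effect. Compound 4 `CCCCCc1ccc(C#Cc2c(-c3ccc(CCCCC)cc3)oc3nc(=O)n(Cc4cn(-c5ccc(Cl)cc5)nn4)cc23)cc1` carries the change (4-chlorophenyl in place of 2-fluorophenyl on an aromatic nitrogen). No measured step bears on this exchange, and nothing shown points to a shift in this assay. Compound 4 is expected to remain at the limit, an estimated 150000 nM within 60000 nM to 400000 nM, so the expected step that the limit leaves unreadable from compound 3 to compound 4 is none beyond the scatter.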

Compound 4, half-maximal inhibitory concentration: > 100000 nM
Compound 4: only a limit was reported; the forecaster's own chance of this, stated with the estimate: 75%; the middle value lies beyond the limit too.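

No step can be read among compound 2, compound 3 and compound 4, because each gives only a limit: the limit of > 100000 nM in this assay, at which 3 of the 4 values shown sit.

The compounds shown leave open whether exchanging the group on this aromatic nitrogen changes the result in this assay at all.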